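Chloro in place of nitro: compound 3 to compound 4

The compounds below may be only part of what the source reports. "The series", "measured", "known", "first", "only" and "open" are said of these compounds alone.

Measured in a functional assay on A-431 cells (Homo sapiens) for antiproliferative activity, read by CCK-8 assay, with a stated time of 72 h (a lower number here means a stronger inhibitor, a higher number a weaker inhibitor), so far:
- compound 1 `Cc1cc(Nc2cc(N3CCN(C)CC3)nc(Nc3ccc(S(N)(=O)=O)cc3)n2)n[nH]1` gives 2760 nM 
- compound 2 `Cc1cc(Nc2cc(N3CCN(C)CC3)nc(Nc3ccc(Cl)cc3)n2)n[nH]1` gives 162 nM 
- compound 3 `Cc1cc(Nc2cc(N3CCN(C)CC3)nc(Nc3cccc([N+](=O)[O-])c3)n2)n[nH]1` gives 166 nM 

Compound 3 lies within the scatter of compound 2, and the gap to compound 1 is large, a 17-fold lower number from compound 1 to compound 3 (1.22 log units; beyond the scatter). Compound 4 `Cc1cc(Nc2cc(N3CCN(C)CC3)nc(Nc3cccc(Cl)c3)n2)n[nH]1` carries chloro in place of nitro on an aromatic carbon, meta to a large group (chloro in place of nitro on an aromatic carbon). Going by the values given here, two measured steps bear on this. Chloro in place of sulfamoyl gave a 17-fold lower number from compound 1 to compound 2 (1.23 log units; beyond the scatter), and 3-nitrophenyl in place of 4-chlorophenyl gave a 1.0-fold higher number from compound 2 to compound 3 (0.01 log units; within the scatter). The second step is the closer guide, so no step beyond the scatter is expected in this assay. The estimate amounts to an expected 1.0-fold lower number from compound 3 to compound 4 (0.02 log units; within the scatter). For compound 4 the expected value is 160 nM, with an estimated range of 70 nM to 370 nM.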

Compound 4, half-maximal inhibitory concentration: 87.5 nM
Estimate against measurement, compound 4: 1.8-fold (0.26 log units) above; low and high end bracket the measured number.
By their numbers in this assay, from the lowest: compounds 4, 2 and 3 (each within the scatter of the next); then compound 1.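

In this assay, exchanging nitro for chloro on this aromatic carbon gives a 1.9-fold lower number from compound 3 to compound 4 (0.28 log units; within the scatter), and 3-chlorophenyl in place of 4-chlorophenyl gives a 1.9-fold lower number from compound 2 to compound 4 (0.27 log units; within the scatter), so neither change separates these compounds beyond the scatter. The step with 3-chlorophenyl in place of 4-sulfamoylphenyl, a 32-fold lower number from compound 1 to compound 4 (1.50 log units; beyond the scatter), leaves compound 1 well apart from compound 4. Nothing available explains these numbers.

Open, on these data alone, is whether an amine, a carboxylic acid or a longer chain at this place would give numbers like those of compound 2, compound 3 and compound 4 or like that of compound 1. Also open, as far as these compounds go, is how 3-sulfamoylphenyl would compare with 4-sulfamoylphenyl.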